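Amide nitrogen substitution on the compound 3 scaffold

This account rests on a few compounds, and the source may have more. Where it says the series, first, only, none or still open, it means among the compounds named here.

Compound 1 `Cc1cc(C(=O)O)nn1Cc1cc(Cl)cn2nc(C(C)C)cc12` — a limit of the assay, > 1000 nM in an assay on CHO-K1 cells for displacement of a labelled ligand from prostaglandin E2 receptor EP1 subtype (Homo sapiens), read by scintillation counting, with a stated time of 45 min; a lower number here means a stronger inhibitor, a higher number a weaker inhibitor
Compound 2 `CO[C@H]1CC[C@H](NC(=O)c2cc(C)n(Cc3cc(Cl)cc4cc(C(C)C)oc34)n2)CC1` — 316 nM in this assay
Compound 3 `Cc1cc(C(N)=O)nn1Cc1cc(Cl)cc2cc(-c3ccccc3)oc12` — 5.01 nM in this assay

Compound 3 holds the lowest of the two numbers shown; compound 2 sits a long way higher, beyond the scatter, while compound 1 gives only a limit (the limit of > 1000 nM in this assay, at which 1 of the 3 values shown sits). Compound 2 and compound 3 differ in several places at once, so nothing is known about the amide substitution on its own.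

Compound 4 `Cc1cc(C(=O)NCC2CCNCC2)nn1Cc1cc(Cl)cc2cc(-c3ccccc3)oc12` keeps the whole of compound 3 and changes one thing: (piperidin-4-yl)methyl in place of hydrogen on an amide-type nitrogen — amino to ((piperidin-4-yl)methyl)amino, carbamoyl to ((piperidin-4-yl)methyl)carbamoyl. Within the data shown here, no measured pair isolates this change. The only secondary amide measured, compound 2, gives a high number, but its other differences from compound 3 leave the cause open.

Working expectation: a moderate loss, beyond the scatter, with wide uncertainty in both directions. The step from compound 3 to compound 4 is estimated as a 6.0-fold higher number from compound 3 to compound 4 (0.78 log units; beyond the scatter). Compound 4 is therefore expected at about 30 nM, within 5 nM to 200 nM.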

Compound 4, half-maximal inhibitory concentration: 20 nM
Beside the measured number, compound 4's estimate is 1.5-fold (0.18 log units) above it, and the stated range covers the measured number.
By their numbers in this assay, from the lowest: compound 3; then compound 4; then compound 2. At a limit, above all of these: compound 1.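

In this assay, the amide-type nitrogen of compound 3 takes (piperidin-4-yl)methyl in place of hydrogen with a 4.0-fold higher number from compound 3 to compound 4 (0.60 log units; beyond the scatter) and the step is modest. Among these compounds, this is the first reading of the amide substitution on its own, which the earlier compounds could not give: the primary amide is not essential to a low number on this scaffold, and a substituent carrying a six-membered non-aromatic ring is accepted on that nitrogen at a limited cost. Nothing measured here accounts for the size of this step.

Going by these compounds, a single substituent cannot separate the contributions of the ring nitrogen, the ring itself and the linking carbon, so it remains open how a cyclohexylmethyl group, a plain methyl group or a piperidine ring joined directly to the amide nitrogen would compare. On these data alone, it is equally open whether a longer chain ending in a primary amine, or a second substituent on the same nitrogen to give a tertiary amide, would keep the number in this range.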